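Oxadiazolyl for trifluoromethyl on the shared core

The source may report more compounds than this note shows. Statements on the series, on what has been measured and on what is new or still open speak of the compounds shown alone.

Compound 1 `C[C@@H](Nc1nccc(Cl)c1NC(=O)CC#N)c1ccc(-c2cccc(F)c2C(F)(F)F)cc1` has no result in a functional assay on CHO cells for antagonist activity at B1 bradykinin receptor (Homo sapiens), read by FLIPR and calcium flux; on this read-out lower numbers stand for stronger inhibition and higher numbers for weaker inhibition; for compound 1 the record shows "not determined" (no result reported), so no number is available for it. Its two measured relatives, compound 2 `COC(=O)c1c(Cl)cccc1-c1ccc([C@@H](C)Nc2nccc(Cl)c2NC(=O)CC#N)cc1` with 0.85 nM and compound 3 `COC(=O)c1ccc(Cl)cc1-c1ccc([C@@H](C)Nc2nccc(Cl)c2NC(=O)CC#N)cc1` with 1.5 nM, differ only in the placement of the chloro and methoxycarbonyl groups, and the step of a 1.8-fold higher number from compound 2 to compound 3 (0.25 log units; within the scatter) shows that this rearrangement leaves potency unchanged. Compound 4 `Cc1nc(-c2c(F)cccc2-c2ccc([C@@H](C)Nc3nccc(Cl)c3NC(=O)CC#N)cc2)no1` arises from compound 1 by 5-methyl-1,2,4-oxadiazol-3-yl in place of trifluoromethyl on an aromatic carbon. For the measured compounds named here, no measured pair bears directly on this exchange, so the size of the step in this assay cannot be read from the data; the only guide is that both measured analogues sit at low single-digit nanomolar values. Compound 4 is therefore expected near 1.5 nM, within 0.3 nM to 8 nM.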

Compound 4, half-maximal inhibitory concentration: 0.78 nM
Compound 4: middle estimate off by 1.9-fold (0.28 log units), on the high side, within the range that was stated.
By their numbers in this assay, from the lowest: compounds 4, 2 and 3 (each within the scatter of the next).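

For the compounds shown here, no step to compound 4 can be read, as compound 1 has no number in this assay on the shared core. Left open is how 5-methyl-1,2,4-oxadiazol-3-yl compares with trifluoromethyl at this place. No supporting data bear on the result.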